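The source may report more compounds than this note shows. Statements on the series, on what has been measured and on what is new or still open speak of the compounds shown alone.

Three compounds of this series have numbers in an ADME assay on A549 cells (Homo sapiens) for cytotoxicity, read by resazurin assay, with a stated time of 48 h; a lower number here means that less compound is tolerated, a higher number that more compound is tolerated. Compound 1 `CCN(CC)c1ccc(NC(=O)c2cc(Cl)ccc2O)c(Cl)c1` gives 55500 nM. Compound 2 `O=C(Nc1ccc(NCc2ccc(F)cc2)cc1Cl)c1cc(Cl)ccc1O` gives 54400 nM. Compound 3 `O=C(Nc1ccc(NCc2ccc(C(F)(F)F)cc2)cc1Cl)c1cc(Cl)ccc1O` gives 62700 nM, the highest of the three numbers, though each of its gaps to the other two lies within the scatter. The two steps in hand, a 1.0-fold lower number from compound 1 to compound 2 (0.01 log units; within the scatter) and a 1.2-fold higher number from compound 2 to compound 3 (0.06 log units; within the scatter), both fall within the scatter. Compound 4 `O=C(Nc1ccc(NCc2ccc(Br)s2)cc1Cl)c1cc(Cl)ccc1O` differs from compound 3 by 5-bromothiophen-2-yl in place of 4-(trifluoromethyl)phenyl on a saturated chain carbon bound to a nitrogen on an aromatic ring. For the measured compounds named here, no measured step exchanges one aromatic ring for another; the steps available, a change of the substituent on that ring in a 1.2-fold higher number from compound 2 to compound 3 (0.06 log units; within the scatter) and a change of the whole amine in a 1.0-fold lower number from compound 1 to compound 2 (0.01 log units; within the scatter), both left this assay unmoved. The expected step, a 1.1-fold lower number from compound 3 to compound 4 (0.03 log units; within the scatter), stays within the scatter. Compound 4 is estimated at 58000 nM, with a range of 35000 nM to 95000 nM.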

Compound 4, half-maximal cytotoxic concentration: 20700 nM
Compound 4: middle estimate off by 2.8-fold (0.45 log units), on the high side; the measured number lies below the stated range.
By their numbers in this assay, from the lowest: compound 4; then compounds 2, 1 and 3 (each within the scatter of the next).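

In this assay the saturated chain carbon bound to a nitrogen on an aromatic ring proves sensitive to exchange of the ring itself, although the change from fluoro to trifluoromethyl on that ring stayed within the scatter: 5-bromothiophen-2-yl gives a 3.0-fold lower number from compound 3 to compound 4 (0.48 log units; beyond the scatter) and a 2.6-fold lower number from compound 2 to compound 4 (0.42 log units; beyond the scatter) in place of the two phenyl groups. Against the diethylamino compound the step is a 2.7-fold lower number from compound 1 to compound 4 (0.43 log units; beyond the scatter) and is likewise beyond the scatter. No evidence at hand bears on what underlies this shift. Going by these compounds, whether it follows the five-membered ring or the bromine stays open. Thiophen-2-yl and 4-bromophenyl on the same carbon would separate the two.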